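The source may hold more compounds than are shown below. What is called first, only, known or untested is meant among the compounds shown, and "the series" means these compounds.

Compound 1, `O=C(c1ccc(OCCCN2CC[C@H](NS(=O)(=O)c3ccc(Br)cc3)C2)cc1)C1CC1`, gives 290 nM in an assay on isolated protein for binding affinity to histamine H2 receptor (Homo sapiens); a higher number here means a weaker inhibitor, a lower number a stronger inhibitor.
Compound 2, `N#Cc1ccc(S(=O)(=O)N[C@H]2CCN(CCCOc3ccc(C(=O)C4CC4)cc3)C2)cc1`, gives 1600 nM in this assay.
Compound 3, `O=C(c1ccc(OCCCN2CC[C@H](NS(=O)(=O)c3ccccc3)C2)cc1)C1CC1`, gives 1200 nM in this assay.

Compound 3 stands second highest of the three numbers; it sits within the scatter of compound 2 and is separated from compound 1 by a 4.1-fold higher number from compound 1 to compound 3 (0.62 log units; beyond the scatter). Compound 4, `O=C(c1ccc(OCCCN2CC[C@H](NS(=O)(=O)c3cccc(Cl)c3)C2)cc1)C1CC1`, differs from compound 3 by chloro in place of hydrogen on an aromatic carbon. Among the compounds with values here, the steps that bear on this are a 4.1-fold higher number from compound 1 to compound 3 (0.62 log units; beyond the scatter) and a 5.5-fold higher number from compound 1 to compound 2 (0.74 log units; beyond the scatter), which show that a halogen on that ring gave a lower number than hydrogen or cyano. A halogen entering at a different place is therefore expected to lower the number in this assay by a modest step, a 2.0-fold lower number from compound 3 to compound 4 (0.30 log units; within the scatter). Compound 4 is estimated at 600 nM, in the range 250 nM to 1500 nM.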

Compound 4, inhibition constant: 700 nM
Beside the measured number, compound 4's estimate is 1.2-fold (0.07 log units) below it; the measured number falls inside the stated range.
By their numbers in this assay, from the lowest: compound 1; then compounds 4, 3 and 2 (each within the scatter of the next, the first and the last beyond it).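

Chloro in place of hydrogen, meta to a large group, leaves only a small step in this assay, namely a 1.7-fold lower number from compound 3 to compound 4 (0.23 log units; within the scatter). The 3-chlorophenyl group stands apart from both other sulfonyl substituents, with a 2.3-fold lower number from compound 2 to compound 4 (0.36 log units; beyond the scatter) and a 2.4-fold higher number from compound 1 to compound 4 (0.38 log units; beyond the scatter), so this halogen at this place does not match the 4-bromophenyl group. Nothing given here accounts for these steps.

As far as these compounds go, whether bromo at this same place would match the 4-bromophenyl group stays open. So does how a methoxy group or an amine on this ring would compare.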